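The compounds below may be only part of what the source reports. "The series", "measured", "known", "first", "only" and "open" are said of these compounds alone.

Three compounds share one core and have been run in a functional assay on the whole organism for inhibition, with Mus musculus as the target, in the writhing test, with a stated time of 15 min, at a dose of 10 mg/kg; on this read-out lower numbers stand for less inhibition and higher numbers for more inhibition at the one dose given (going by the name of the read-out). Compound 1, `O=C1N=C(C2C(=O)c3ccccc3C2=O)CC(c2ccccc2)N1`, carries a phenyl group on a saturated ring carbon and gives 31%. Compound 2, `O=C1N=C(C2C(=O)c3ccccc3C2=O)CC(/C=C/c2ccccc2)N1`, gives 16%, and compound 3, `CN(C)c1ccc(C2CC(C3C(=O)c4ccccc4C3=O)=NC(=O)N2)cc1`, gives 52%. Compound 3 stands highest of the three: the step of a number 21 percentage points higher from compound 1 to compound 3 (beyond the scatter) and the step of a number 36 percentage points higher from compound 2 to compound 3 (beyond the scatter) both lie beyond the scatter, so on these numbers its inhibition in this assay is the highest of the measured set.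

Compound 4, `O=C1N=C(C2C(=O)c3ccccc3C2=O)CC(c2ccco2)N1`, is not yet measured. It differs from compound 3 in one place: furan-2-yl in place of 4-(dimethylamino)phenyl on a saturated ring carbon.

Among the measured compounds shown here, two measured steps bear on this change. Both alter the same saturated ring carbon. The step of a number 21 percentage points higher from compound 1 to compound 3 (beyond the scatter) shows that adding the dimethylamino group to the phenyl ring raised the read-out, and the step of a number 36 percentage points higher from compound 2 to compound 3 (beyond the scatter) shows an even larger rise for swapping the whole group. For the measured compounds named here, compound 4 gives up the dimethylamino group entirely, and a furan-2-yl ring has no measured counterpart here, so the value is expected to fall back toward that of compound 1 or lower. The estimated step is a number 24 percentage points lower from compound 3 to compound 4 (beyond the scatter). For compound 4 the expected value in this assay is 28%, with a range from 10% to 45%.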

Compound 4, a percentage reported as inhibition, in the whole organism at one dose (the size of the read-out at that dose, not a potency): 25%
The estimate for compound 4 lay 3 percentage points above the measured number; the range from low to high includes it.
By their numbers in this assay, from the lowest: compounds 2, 4 and 1 (each within the scatter of the next, the first and the last beyond it); then compound 3.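

In this assay a number 27 percentage points lower from compound 3 to compound 4 (beyond the scatter) shows that the high number of compound 3 does not carry over when a five-membered aromatic ring with one oxygen takes the place of 4-(dimethylamino)phenyl on this saturated ring carbon. Furan-2-yl also cannot be told apart from phenyl or from 2-phenylethenyl on this read-out: the change from phenyl gives a number 6 percentage points lower from compound 1 to compound 4 (within the scatter) and the change from 2-phenylethenyl gives a number 9 percentage points higher from compound 2 to compound 4 (within the scatter). Compound 3 alone now stands clear of all three other compounds, and nothing at hand explains why this one group stands apart.

Still open, as far as these compounds go, is whether the higher number depends on the dimethylamino group itself, or whether a plain amino group, a methoxy group or a pyrrolidine ring on the same phenyl ring would give a similar result. From the compounds shown here alone, with a single dose for every compound, it is also open whether these differences would hold at other doses, and how a group without an aromatic ring, such as cyclohexyl, would behave at this carbon.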